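The source may hold more compounds than are shown below. What is called first, only, known or untested is meant among the compounds shown, and "the series" means these compounds.

Working notes on the series

The compounds share one core. Compound 1 `COc1ccc(-c2c(S(=O)(=O)c3ccc(C)c(F)c3)cnc3c(F)cccc23)cc1` carries a 3-fluoro-4-methylphenyl on the sulfonyl sulfur; in an ADME assay on microsomes from liver (Homo sapiens) for metabolic stability, tested at 2.5 uM (a lower number here means slower removal, a higher number faster removal of the compound), compound 1 gives 3.27 mL/min. For the measured compounds named here, compound 2 `N#Cc1cccc(S(=O)(=O)c2cnc3c(F)cccc3c2-c2cccc(Cl)c2)c1` carries a 3-cyanophenyl in that place; in this assay compound 2 gives 1.11 mL/min, the lower of the two numbers so far, and its gap to compound 1 lies beyond the usual scatter. Going by the values given here, no two measured compounds differ in one place only, so no single change can be sized from the data.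

Compound 3 `Cc1ccc(S(=O)(=O)c2cnc3c(F)cccc3c2-c2cccc(Cl)c2)cc1F` differs from compound 2 in one place: 3-fluoro-4-methylphenyl in place of 3-cyanophenyl on a sulfonyl sulfur. The group that enters is the same one compound 1 carries on its sulfonyl sulfur, while the rest of compound 3 matches compound 2. Among the compounds with values here, compound 1 and compound 3 still differ in another place, and that difference has no measured step behind it. Within the data shown here, with compound 1 at 3.27 mL/min as the only guide, a rise in this assay beyond the scatter is expected, estimated at a 2.2-fold higher number from compound 2 to compound 3 (0.33 log units; beyond the scatter). For compound 3, this assay is expected to give 2.4 mL/min, within 1.2 mL/min to 4.8 mL/min.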

Compound 3, intrinsic clearance in a liver preparation (reported as CLH), per the amount of preparation that the assay uses: 3.18 mL/min
Compound 3: the middle estimate sits 1.3-fold (0.12 log units) below what was measured; low and high end bracket the measured number.
By their numbers in this assay, from the lowest: compound 2; then compounds 3 and 1 (each within the scatter of the next).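

The change on the sulfonyl sulfur can now be sized: with 3-chlorophenyl held on the aromatic carbon, 3-fluoro-4-methylphenyl in place of 3-cyanophenyl gives a 2.9-fold higher number from compound 2 to compound 3 (0.46 log units; beyond the scatter) in this assay, so this one exchange accounts for the whole gap that separated compound 2 from the other numbers. With 3-fluoro-4-methylphenyl held on the sulfonyl sulfur, 3-chlorophenyl in place of 4-methoxyphenyl on an aromatic carbon gives a 1.0-fold lower number from compound 1 to compound 3 (0.01 log units; within the scatter), so in this pair this assay does not tell the two groups apart. No measurement at hand bears on why 3-cyanophenyl on the sulfonyl sulfur gives the lowest number of the three.

On these data alone, each step rests on a single pair, so it remains open whether the exchange on the sulfonyl sulfur would give a similar step with 4-methoxyphenyl on the aromatic carbon. As far as these compounds go, it also remains open where this assay would place a compound with a pyridine ring, an amine or a longer alkyl chain on the sulfonyl sulfur.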